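Swapping the Side Chain of Compound 3

The source may hold more compounds than are shown below. What is called first, only, known or untested is meant among the compounds shown, and "the series" means these compounds.

- Compound 1 `CCCCNc1nc(N)c2nc(O)n(Cc3ccc(C)cc3)c2n1`: < 1000 ug/mL, a limit of the assay and not a number
- Compound 2 `CCCCNc1nc(N)c2[nH]c(=O)n(Cc3ccc(N4CCCCC4)cc3)c2n1`: 19000 ug/mL
- Compound 3 `CCCCNc1nc(N)c2[nH]c(=O)n(Cc3ccc(OCCCN(C)C)nc3)c2n1`: 288000 ug/mL

All three compounds were read in a physicochemical assay for solubility, at pH 7.4; on this read-out higher numbers stand for higher solubility and lower numbers for lower solubility. Only two of them give true numbers, and compound 3 stands the higher of these at 288000 ug/mL. Compound 2 lies at 19000 ug/mL, a gap well beyond the usual scatter of repeated measurements.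

The next compound to be measured is compound 4 `CCCCNc1nc(N)c2[nH]c(=O)n(Cc3ccc(N4CCC(N(C)C)CC4)nc3)c2n1`. It carries 4-(dimethylamino)piperidin-1-yl in place of 3-(dimethylamino)propoxy on an aromatic carbon, next to the ring nitrogen and para to a large group (4-(dimethylamino)piperidin-1-yl in place of 3-(dimethylamino)propoxy on an aromatic carbon). The dimethylamino unit appears in both names, so part of the group stays the same, while a six-membered non-aromatic ring replaces the open chain.

Going by the values given here, no measured pair differs in just one place, so this expectation rests on little. Compound 3 at 288000 ug/mL serves as the upper guide, and compound 2 at 19000 ug/mL as a loose lower one. In this assay a modest fall is expected, an estimated 1.6-fold lower number from compound 3 to compound 4 (0.20 log units; within the scatter). For compound 4 the estimated value is 180000 ug/mL, with an expected range from 40000 ug/mL to 600000 ug/mL.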

Compound 4, solubility: 71000 ug/mL
Compound 4: the middle estimate sits 2.5-fold (0.40 log units) above what was measured; low and high end bracket the measured number.
By their numbers in this assay, from the lowest: compound 2; then compound 4; then compound 3. At a limit, below all of these: compound 1.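

In this assay, going by these compounds alone, the first step between two compounds that differ in one place is a 4.1-fold lower number from compound 3 to compound 4 (0.61 log units; beyond the scatter), so the read-out at this position, on an aromatic carbon next to the ring nitrogen and para to a large group, depends on what is attached there. The change keeps the dimethylamino unit and the printed count of hydrogen-bond donors and acceptors, yet the value still moves beyond the usual scatter when 3-(dimethylamino)propoxy, which has no ring, gives way to 4-(dimethylamino)piperidin-1-yl, which has one six-membered non-aromatic ring. Nothing measured here shows which part of this swap, the lost oxygen or the added ring, accounts for the lower number.

A 3-(dimethylamino)propylamino chain at the same position would keep the open chain while replacing the oxygen with a nitrogen, and so would help separate those two parts of the change. A morpholine ring or a carboxylic acid at this position also remains open, as the compounds shown say nothing about groups without the dimethylamino unit on this aromatic ring.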